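From Hydrogen to Butyl on the Aromatic Ring

The compounds below may be only part of what the source reports. "The series", "measured", "known", "first", "only" and "open" are said of these compounds alone.

Compound 1 `O=C(Nc1ccccc1)C1CCN(C/C=C/c2ccccc2)CC1` and compound 2 `CCc1ccc(NC(=O)C2CCN(C/C=C/c3ccccc3)CC2)cc1` were both tested in a functional assay on MCF7 cells (Homo sapiens) for inhibition, read by MTT assay, with a stated time of 72 h; on this read-out higher numbers stand for weaker inhibition and lower numbers for stronger inhibition. In this assay compound 1 gives 60200 nM, the highest of the two numbers shown, while its nearest neighbour, compound 2, gives 20000 nM. The step of a 3.0-fold lower number from compound 1 to compound 2 (0.48 log units; beyond the scatter) comes from ethyl in place of hydrogen on an aromatic carbon, and it lies beyond the scatter. Compound 3 `CCCCc1ccc(NC(=O)C2CCN(C/C=C/c3ccccc3)CC2)cc1` has not yet been measured; it differs from compound 1 by butyl in place of hydrogen on an aromatic carbon. Among the measured compounds shown here, the only measured step that bears on this change is a 3.0-fold lower number from compound 1 to compound 2 (0.48 log units; beyond the scatter), which was modest. A longer chain at that place is expected to move the number in the same direction, by a step of similar or somewhat larger size. Compound 3 is therefore expected to give 12000 nM in this assay, within 4000 nM to 40000 nM. This estimate means a step of a 5.0-fold lower number from compound 1 to compound 3 (0.70 log units; beyond the scatter).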

Compound 3, half-maximal inhibitory concentration: 5870 nM
Compound 3: the middle estimate sits 2.0-fold (0.31 log units) above what was measured, and the stated range covers the measured number.
By their numbers in this assay, from the lowest: compound 3; then compound 2; then compound 1.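

In this assay butyl on an aromatic carbon, para to a large group, gives a 10-fold lower number from compound 1 to compound 3 (1.01 log units; beyond the scatter) and so a large step, where the earlier compounds had shown only a modest one for ethyl. The extra length of chain counts in its own right: going from ethyl to butyl gives a 3.4-fold lower number from compound 2 to compound 3 (0.53 log units; beyond the scatter) and this too lies beyond the scatter, so among these three compounds the number falls with each lengthening of the chain, and none goes against that order. Nothing shown here gives a reason for this change.

On these data alone, whether the number keeps falling with a longer chain such as hexyl, or levels off, remains open. So does whether a branched chain such as tert-butyl, or a butyl chain ending in an amine or a carboxylic acid, would behave the same way at this place.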